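A few compounds are considered here, and "the series" means these few. Any claim that something is new, unique, unknown or untested is made for them only; others in the source may bear on it.

In an ADME assay on CHO cells (Cricetulus griseus) for cytotoxicity, read by MTT assay (a higher number here means that more compound is tolerated, a lower number that less compound is tolerated), compound 1 `Fc1ccc(Nc2cc3[nH]c(Nc4ccc(N5CCNCC5)cn4)nc3cn2)cc1C(F)(F)F` gives 14000 nM, while compound 2 `Fc1ccc(Nc2cc3[nH]c(Nc4ccc(N5CCNCC5)cn4)nc3cn2)cc1F` gives 33000 nM, the higher of the two numbers. Compound 3 `C[C@@H]1CN(c2ccc(Nc3nc4cnc(Nc5ccc(F)c(F)c5)cc4[nH]3)nc2)C[C@H](C)N1` differs from compound 2 in one group: 3,5-dimethylpiperazin-1-yl in place of piperazin-1-yl on an aromatic carbon. Here 3,5-dimethylpiperazin-1-yl stands in place of piperazin-1-yl on an aromatic carbon of a six-membered aromatic ring with 1 nitrogen. Going by the values given here, only one measured step is available, and it bears on this change only indirectly: a 2.4-fold higher number from compound 1 to compound 2 (0.37 log units; beyond the scatter). That modest step came from fluoro in place of trifluoromethyl, at a different place in the molecule. Among the compounds with values here, no measured pair changes the piperazin-1-yl group, so the data give no direct guide to direction. No step beyond the scatter is therefore expected in this assay. The expected step is a 1.3-fold lower number from compound 2 to compound 3 (0.10 log units; within the scatter). Compound 3 is estimated at 26000 nM, with an expected range of 11000 nM to 60000 nM.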

Compound 3, half-maximal cytotoxic concentration in the CHO assay: 2700 nM
Estimate against measurement, compound 3: 9.6-fold (0.98 log units) above; the whole stated range lies above it.
By their numbers in the CHO assay, from the lowest: compound 3; then compound 1; then compound 2.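

Going by these compounds alone, in the CHO assay, the first measured change at this position, on an aromatic carbon two atoms from the ring nitrogen, gives a 12-fold lower number from compound 2 to compound 3 (1.09 log units; beyond the scatter) on going from piperazin-1-yl to 3,5-dimethylpiperazin-1-yl, so the number in this assay depends strongly on the group at this place, which the earlier pair left untouched. The same change goes with far higher solubility in a physicochemical assay for solubility, read by HPLC, using the shake flask method, in phosphate buffer, measured as kinetic solubility, with a stated time of 20 h, at pH 6.5 (a lower number here means a less soluble compound, a higher number a more soluble compound), so tolerance and solubility move in opposite directions across this one pair: the measured solubility of compound 2, < 5000 nM, and of compound 3, 175000 nM, an at least 35-fold higher number (1.54 log units; beyond the scatter). In the physicochemical assay compound 3 gives 175000 nM. In the physicochemical assay compound 2 gives < 5000 nM as a limit of the assay and not a number: the limit of < 5000 nM in the physicochemical assay, at which 1 of the 2 values shown sits.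

The compounds shown leave open how a piperazine carrying a single methyl, or a morpholine, would behave in either assay. They also leave open whether another stereoisomer of the dimethylpiperazine would give the same numbers.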